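Phenyl-for-phenoxy swap on the benzoxazole series

The compounds below may be only part of what the source reports. "The series", "measured", "known", "first", "only" and "open" are said of these compounds alone.

Measured so far:
compound 1, `CCc1ccc2nc(-c3cc(-c4cnn(C5CCNCC5)c4)cnc3N)oc2c1O`, 3400 nM
compound 2, `Nc1ncc(-c2cnn(C3CCNCC3)c2)cc1-c1nc2ccc(Oc3ccccc3)cc2o1`, 4000 nM

Both compounds were run in an assay on isolated protein for inhibition of G protein-coupled receptor kinase 5 (Homo sapiens), read by TR-FRET, with stated times of 10 min and 1 h; a lower number here means a stronger inhibitor, a higher number a weaker inhibitor. Compound 1 gives 3400 nM. Compound 2 gives 4000 nM; this is nominally the higher of the two numbers, but the gap to compound 1 lies within the scatter of repeat runs, so the two cannot be separated on what is in hand.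

Compound 3, `COc1ccc(-c2ccc3nc(-c4cc(-c5cnn(C6CCNCC6)c5)cnc4N)oc3c2)cc1`, has not yet been measured. It differs from compound 2 in one place: 4-methoxyphenyl in place of phenoxy on an aromatic carbon. The directly bonded aryl group replaces an oxygen-linked one on the same aromatic carbon of the shared core.

Within the data shown here, no measured pair isolates this kind of change, so there is no precedent for its size or direction. With the two known values sitting so close together, the default expectation is a step no larger than the scatter, in either direction.

For compound 3 in this assay the estimate is 3500 nM, with a range of 1000 nM to 12000 nM. The expected step that this estimate implies is a 1.1-fold lower number from compound 2 to compound 3 (0.06 log units; within the scatter), which would stay within the usual scatter.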

Compound 3, half-maximal inhibitory concentration: 3220 nM
Compound 3: middle estimate off by 1.1-fold (0.04 log units), on the high side; the measured number falls inside the stated range.
By their numbers in this assay, from the lowest: compounds 3, 1 and 2 (each within the scatter of the next).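

In this assay, 4-methoxyphenyl in place of phenoxy on this aromatic carbon gives a 1.2-fold lower number from compound 2 to compound 3 (0.09 log units; within the scatter) and so stays within the scatter. Among these compounds, this is the first pair to isolate a single-place change, and it shows that the oxygen-linked aryl group and the directly bonded aryl group cannot be told apart at this position in this assay. The swap also enters a larger group that carries its oxygen on a methoxy rather than as the link, yet neither difference in the pair produces a step that can be read, although the two differences are not separated from each other and could be offsetting.

The plain phenyl group on the same aromatic carbon would separate the loss of the oxygen link from the addition of the methoxy, while an aminomethyl or carboxylic acid on the 4-position of the phenyl ring would test whether anything at this place can move the number beyond the scatter. Nothing at hand accounts for the flat step between these two compounds.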